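This account rests on a few compounds, and the source may have more. Where it says the series, first, only, none or still open, it means among the compounds named here.

Measured compounds:
compound 1 `C=C(c1ccc(OC)cc1NC(=O)CO)c1ccc(OC)c2c1OC(C)(C)C=C2` gives 100 nM in a functional assay on MCF7 cells (Homo sapiens) for antiproliferative activity, read by MTT assay, with a stated time of 48 h; a lower number here means a stronger inhibitor, a higher number a weaker inhibitor
compound 2 `C=C(c1ccc2c(c1)C=CC(C)(C)O2)c1ccc(OC)cc1NC(=O)CO` gives 390 nM
compound 3 `C=C(c1ccc(OC)cc1NC(=O)CN)c1ccc(OC)c2c1OC(C)(C)C=C2` gives 220 nM

Compound 1 and compound 3 share one core and differ only in one group: amino in place of hydroxy on a saturated chain carbon bound to a carbonyl carbon. That change gave a 2.2-fold higher number from compound 1 to compound 3 (0.34 log units; beyond the scatter). Compound 2 sits on a different core; how the two cores differ is not broken down here. Compound 4 `C=C(c1ccc2c(c1)C=CC(C)(C)O2)c1ccc(OC)cc1NC(=O)CN` is not yet measured. It relates to compound 2 exactly as compound 3 relates to compound 1: amino in place of hydroxy on a saturated chain carbon bound to a carbonyl carbon. Since the same change at the same place is made, the step from compound 2 is expected to resemble the earlier one, giving a 2.2-fold higher number from compound 2 to compound 4 (0.34 log units; beyond the scatter); this rests on compound 2 standing at 390 nM and on the earlier step. Compound 4 is therefore estimated at 860 nM, expected to lie between 400 nM and 1800 nM.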

Compound 4, half-maximal inhibitory concentration: 420 nM
Compound 4: the middle estimate sits 2.0-fold (0.31 log units) above what was measured, within the range that was stated.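

In this assay, putting amino in place of hydroxy on the saturated chain carbon bound to a carbonyl carbon gave a 1.1-fold higher number from compound 2 to compound 4 (0.03 log units; within the scatter). Set beside the same change on the other core, the two steps do not differ by more than the scatter allows: the same change on two cores in this assay, a 2.2-fold higher number (0.34 log units; beyond the scatter) from compound 1 to compound 3 and a 1.1-fold higher number (0.03 log units; within the scatter) from compound 2 to compound 4, 2.0-fold (0.31 log units) apart, within the scatter of two such steps. So the change shows no clear sign of behaving differently on these two cores, even though only the earlier step lies beyond the scatter, but two pairs do not show that it would carry over to further cores or why the steps came out as they did.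

The compounds shown leave open how a methoxy or dimethylamino group would compare at the same place. They also leave open whether a longer chain carrying the hydroxy or amino group would follow the same pattern on either core.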